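Swapping the ring on the sulfonyl sulfur

The source may hold more compounds than are shown below. What is called first, only, known or untested is meant among the compounds shown, and "the series" means these compounds.

Compound 1 `COc1cccc(S(=O)(=O)c2ccc(NC(=O)C(C)(O)C(F)(F)F)cc2)c1`: 16000 nM
Compound 2 `CC(O)(C(=O)Nc1ccc(S(=O)(=O)c2ccc([N+](=O)[O-])cc2)cc1)C(F)(F)F`: > 30000 nM

In a functional assay (Cavia porcellus) with sulfonylurea receptors; K-ATP channels (Homo sapiens) as the target (on this read-out higher numbers stand for weaker inhibition and lower numbers for stronger inhibition), compound 1 gives 16000 nM. For compound 2 this assay reports only a limit, > 30000 nM, not a measured number (the limit of > 30000 nM in this assay, at which 1 of the 2 values shown sits). Compound 3 `CC(O)(C(=O)Nc1ccc(S(=O)(=O)c2nccs2)cc1)C(F)(F)F` differs from compound 2 by 1,3-thiazol-2-yl in place of 4-nitrophenyl on a sulfonyl sulfur. Among the compounds with values here, the only measured step, an at least 1.8-fold higher number from compound 1 to compound 2 (0.27 log units; that floor lies within the scatter), concerns a different exchange on the same sulfonyl sulfur and is no direct guide, so the size and direction of the coming step are open. Compound 3 is therefore expected to sit near the values already seen, estimated at 20000 nM (range 5000 nM to 60000 nM). The expected step is an at least 1.5-fold lower number from compound 2 to compound 3 (0.17 log units; that floor lies within the scatter).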

Compound 3, half-maximal inhibitory concentration: 1400 nM
Estimate against measurement, compound 3: 14-fold (1.15 log units) above; measured number below the stated range.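

In this assay, the ring on the sulfonyl sulfur turns out to be able to change inhibition strongly: 1,3-thiazol-2-yl gives an at least 21-fold lower number from compound 2 to compound 3 (1.33 log units; beyond the scatter) and an 11-fold lower number from compound 1 to compound 3 (1.06 log units; beyond the scatter). The earlier exchange between two six-membered rings had shown only a floor within the scatter. The first of the new steps is also only a floor, since compound 2 has a limit rather than a number: the limit of > 30000 nM in this assay, at which 1 of the 3 values shown sits.

On these data alone, whether the gain comes from the ring nitrogen, the ring sulfur or the five-membered ring itself stays open. A 1,3-oxazol-2-yl or 2-pyridyl ring on the same sulfur would help separate these.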